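A pyridinyl ester in place of a salicylate: stability outlook

A few compounds are considered here, and "the series" means these few. Any claim that something is new, unique, unknown or untested is made for them only; others in the source may bear on it.

Three esters built on one shared core have been followed in an ADME assay on a cell-free system (plasma, Homo sapiens) for metabolic stability, with Plasma (Rattus norvegicus) as the target, read by HPLC, at pH 7.4; a lower number here means that the compound disappears faster, a higher number that the compound lasts longer. Compound 1 `CC(=O)Oc1ccccc1C(=O)O[C@H]1CO[C@H]2[C@@H]1OC[C@H]2OC(=O)c1ccccc1O` gives 0.0825 h in this assay. Compound 2 `CC(=O)Oc1ccccc1C(=O)O[C@H]1CO[C@H]2[C@@H]1OC[C@H]2OC(=O)c1ccnn1C` gives 0.0963 h, and compound 3 `CC(=O)Oc1ccccc1C(=O)O[C@H]1CO[C@H]2[C@@H]1OC[C@H]2OC(=O)C1CC1` gives 0.0322 h. Among these three numbers compound 1 stands second highest: compound 2 is nearest to it, while compound 3 lies furthest away.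

Compound 4 `CC(=O)Oc1ccccc1C(=O)O[C@H]1CO[C@H]2[C@@H]1OC[C@H]2OC(=O)c1cccnc1` has not yet been measured. It differs from compound 1 at one point: pyridin-3-yl in place of 2-hydroxyphenyl on a carbonyl carbon. Two measured steps start from the same group on the same carbonyl carbon. The step of a 1.2-fold higher number from compound 1 to compound 2 (0.07 log units; within the scatter) shows that exchanging the 2-hydroxyphenyl group for a 1-methyl-1H-pyrazol-5-yl ring leaves the half-life essentially unchanged. The step of a 2.6-fold lower number from compound 1 to compound 3 (0.41 log units; beyond the scatter) shows that a cyclopropyl group in that place shortens the half-life. Compound 4 receives a pyridin-3-yl ring, another aromatic heteroaromatic ring, and so resembles compound 2 more than compound 3 in what enters.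

The step from compound 1 to compound 4 is therefore expected to be a 1.0-fold higher number from compound 1 to compound 4 (0.01 log units; within the scatter), that is, no change beyond the scatter. For compound 4 a half-life of about 0.085 h is estimated, with a plausible range from 0.04 h to 0.18 h.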

Compound 4, half-life: 0.0232 h
Compound 4: the middle estimate sits 3.7-fold (0.56 log units) above what was measured; the measured number lies below the stated range.
By their numbers in this assay, from the lowest: compounds 4 and 3 (each within the scatter of the next); then compounds 1 and 2 (each within the scatter of the next).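

At this carbonyl carbon, an aromatic ring in place of 2-hydroxyphenyl does not by itself preserve the half-life in this assay: pyridin-3-yl gives a clear drop (a 3.6-fold lower number from compound 1 to compound 4 (0.55 log units; beyond the scatter)), whereas the 1-methyl-1H-pyrazol-5-yl ring of compound 2 did not. The two aromatic rings containing nitrogen therefore do not behave as one class, and the gap between them is also beyond the scatter (a 4.2-fold lower number from compound 2 to compound 4 (0.62 log units; beyond the scatter)). The pyridin-3-yl ring instead cannot be told apart from the non-aromatic cyclopropyl group (a 1.4-fold lower number from compound 3 to compound 4 (0.14 log units; within the scatter)), and no measurement here explains these differences.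

Compound 4 has lost the hydroxyl of compound 1 and has also gained nitrogen in the six-membered ring. A phenyl group without the hydroxyl would help separate these two changes. Pyridin-2-yl and pyridin-4-yl esters would show whether the half-life of compound 4 is specific to pyridin-3-yl or is shared by other pyridine rings at this carbonyl carbon.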